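This account rests on a few compounds, and the source may have more. Where it says the series, first, only, none or still open, it means among the compounds named here.

Of the compounds shown here, three have so far been measured in a functional assay on cells for agonist activity at C-X-C chemokine receptor type 4 (Homo sapiens), read by fluorescence and calcium flux, with a stated time of 90 s; a lower number here means that less compound is needed, a higher number that more compound is needed for the effect. Compound 1, with the structure `c1ccc(CN(CCCCN(C[C@H]2Cc3ccccc3CN2)[C@H]2CCCc3cccnc32)Cc2ccccn2)nc1`, reaches only the limit of the assay and gives > 30000 nM. Compound 2, built as `c1ccc2c(c1)CN[C@@H](CN(CCCCN(Cc1ccncc1)Cc1ccncc1)[C@H]1CCCc3cccnc31)C2`, likewise stops at the limit and gives > 30000 nM. Compound 3, with the structure `c1ccc2c(c1)CN[C@@H](CN(CCCCNCC1CCOCC1)[C@H]1CCCc3cccnc31)C2`, also ends at the limit and gives > 30000 nM. For the measured compounds named here, compound 3 therefore stands exactly where every measured compound stands, namely at the limit of > 30000 nM in this assay, at which 3 of the 3 values shown sit; no measured compound has a real number in this assay, and no step between two measured compounds can be read.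

Compound 4, with the structure `c1ccc2c(c1)CN[C@@H](CN(CCCCNC1CCCCC1)[C@H]1CCCc3cccnc31)C2`, differs from compound 3 in a single place: cyclohexyl in place of (oxan-4-yl)methyl on an amine nitrogen. With all three measured values sitting at the limit, there is no basis for expecting a step beyond the usual scatter in either direction. Compound 4 is thus expected to come out at the limit again, with an estimate of 40000 nM and a range from 10000 nM to 150000 nM. The step this estimate means, a step that the limit leaves unreadable from compound 3 to compound 4, is expected to be none beyond the scatter.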

Compound 4, half-maximal effective concentration: > 30000 nM
Compound 4 gave a limit, no number; the forecaster's own chance of this, stated with the estimate: 85%; the middle value is on the limit's open side.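

Compound 3 and compound 4 both end at a limit rather than a real number, so no step between them can be read in this assay: the limit of > 30000 nM in this assay, at which 4 of the 4 values shown sit.

The compounds shown leave open which structure, if any, would give a real number in this assay.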